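Swapping pyridin-3-yl for pyridin-2-yl in compound 4

This account rests on a few compounds, and the source may have more. Where it says the series, first, only, none or still open, it means among the compounds named here.

Compound 1 `CC1=C(C(=O)OCc2cccnc2)C(c2ccccc2[N+](=O)[O-])C2=C(CCCC2=O)N1` gives 1.51 in a physicochemical assay for lipophilicity, measured as octanol-water partition; a lower number here means a more polar compound, a higher number a more lipophilic compound. Compound 2 `CC1=C(C(=O)OCc2cccnc2)C(c2ccc([N+](=O)[O-])cc2)C2=C(CCCC2=O)N1` gives 1.51 in this assay, and no change at the digits printed from compound 1 to compound 2 (within the scatter). Compound 3 `CC1=C(C(=O)OCc2cccnc2)C(c2ccc(Br)cc2)C2=C(CCCC2=O)N1` gives 2.05, so that a number 0.54 log units higher from compound 1 to compound 3 (beyond the scatter) and a number 0.54 log units higher from compound 2 to compound 3 (beyond the scatter). Compound 1 therefore stands together with compound 2, with compound 3 higher than both beyond the scatter.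

Compound 4 `CC1=C(C(=O)OCc2ccccn2)C(c2ccccc2[N+](=O)[O-])C2=C(CCCC2=O)N1` differs from compound 1 in one place: pyridin-2-yl in place of pyridin-3-yl on a saturated chain carbon bound to an oxygen next to a carbonyl group. None of the three measured steps bears on this change; all of them concern the group on the saturated ring carbon, and the two pyridinyl isomers carry the same atoms in the same kind of ring. With nothing pointing either way, a step within the scatter is expected for a number 0.01 log units lower from compound 1 to compound 4 (within the scatter). Compound 4 is accordingly estimated at 1.5, between 1.2 and 1.9.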

Compound 4, partition coefficient: 1.88
Estimate against measurement, compound 4: 0.38 log units below, and the stated range covers the measured number.
By their numbers in this assay, from the lowest: compounds 1 and 2 (each within the scatter of the next); then compounds 4 and 3 (each within the scatter of the next).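

In this assay there is a number 0.37 log units higher from compound 1 to compound 4 (beyond the scatter) for pyridin-2-yl in place of pyridin-3-yl, although the two groups have the same atoms, joined differently. This is the first step shown at this place, and it shows that the change of isomer alone can move the number beyond the scatter. No measured evidence accounts for this step.

As far as these compounds go, whether pyridin-4-yl or a plain phenyl at this place would stand nearer compound 1 or compound 4 stays open. So does whether the step recurs with 4-bromophenyl on the saturated ring carbon.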